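The source may hold more compounds than are shown below. What is called first, only, known or untested is meant among the compounds shown, and "the series" means these compounds.

Compound 1 `O=C(NCCCCC(c1ccc(F)cc1)c1ccc(F)cc1)Nc1ccc(Cl)cc1` is the reference point of this small series, and in an ADME assay on isolated protein for inhibition of sodium-dependent dopamine transporter (Homo sapiens) (a higher number here means a weaker inhibitor, a lower number a stronger inhibitor), compound 1 gives 15 nM. Compound 2 `O=C(NCCCCC(c1ccc(F)cc1)c1ccc(F)cc1)Nc1ccc(Cl)c(C(F)(F)F)c1` carries a trifluoromethyl in a second position on the aniline ring, and in this assay compound 2 gives 6.5 nM; the step of a 2.3-fold lower number from compound 1 to compound 2 (0.36 log units; beyond the scatter) is a modest gain. Compound 3 `O=C(NCCCCC(c1ccc(F)cc1)c1ccc(F)cc1)Nc1ccc(Cl)cc1C(F)(F)F` places the trifluoromethyl instead on the carbon bearing the urea nitrogen's neighbour, and in this assay compound 3 gives "not determined" (no result reported), so it has no number to stand on. Compound 4 `Cc1cc(Cl)ccc1NC(=O)NCCCCC(c1ccc(F)cc1)c1ccc(F)cc1` is the next step: methyl in place of trifluoromethyl on an aromatic carbon. For the measured compounds named here, no measured step covers this change directly; the only step at hand, a 2.3-fold lower number from compound 1 to compound 2 (0.36 log units; beyond the scatter), concerns a different position and a different pair of groups, so it bears on compound 4 only loosely. The expectation is therefore anchored on compound 1 and compound 2 rather than on compound 3, with a wide range. Compound 4 is expected to give about 14 nM in this assay, between 5 nM and 45 nM.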

Compound 4, inhibition constant: 118 nM
Estimate against measurement, compound 4: 8.4-fold (0.93 log units) below, and the stated range ends below it.
By their numbers in this assay, from the lowest: compound 2; then compound 1; then compound 4.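

At this position, ortho to a large group, a small methyl is not tolerated as a neutral addition in this assay: the change shows a 7.9-fold higher number from compound 1 to compound 4 (0.90 log units; beyond the scatter), a shift opposite in direction to the gain seen with the other substituted ring. Replacing 4-chloro-3-(trifluoromethyl)phenyl with 4-chloro-2-methylphenyl gives an 18-fold higher number from compound 2 to compound 4 (1.26 log units; beyond the scatter), the largest step in this small set. The direct change from trifluoromethyl to methyl cannot be read, since compound 3 has no value, and nothing available explains the loss.

As far as these compounds go, it remains open whether the loss follows from substitution at this carbon generally or from methyl in particular, which a methoxy group or a nitrile there could test. Also open, from the compounds shown here alone, is how a methyl would behave at the carbon that carries trifluoromethyl in compound 2.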